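Removing a bromine at two different places in a triazole series

The source may hold more compounds than are shown below. What is called first, only, known or untested is meant among the compounds shown, and "the series" means these compounds.

Compound 1 `C=C1C(=O)[C@]23C[C@@]1(O)CC[C@H]2c1ccc(O)c(C)c1[C@@H]3Cn1cc(-c2ccccc2)nn1` gives 1740 nM in a functional assay on MCF7 cells (Homo sapiens) for cytotoxicity, read by MTT assay, with a stated time of 4 days; on this read-out lower numbers stand for stronger inhibition and higher numbers for weaker inhibition.
Compound 2 `C=C1C(=O)[C@]23C[C@@]1(O)CC[C@H]2c1ccc(O)c(C)c1[C@@H]3Cn1cc(-c2ccc(Br)cc2)nn1` gives 270 nM in this assay.
Compound 3 `C=C1C[C@]23C[C@@]1(O)CC[C@H]2c1cc(Br)c(O)c(C)c1[C@@H]3Cn1cc(-c2ccc(Cl)cc2)nn1` gives 10200 nM in this assay.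

Compounds 1 and 2 share one core and differ only by hydrogen in place of bromo on an aromatic carbon; that change gave a 6.4-fold higher number from compound 2 to compound 1 (0.81 log units; beyond the scatter). Compound 3 carries a chlorine-bearing phenyl instead, and the difference between its core and that of compound 2 is not broken down here. Compound 4 `C=C1C[C@]23C[C@@]1(O)CC[C@H]2c1ccc(O)c(C)c1[C@@H]3Cn1cc(-c2ccc(Cl)cc2)nn1` is compound 3 with hydrogen in place of bromo on an aromatic carbon. This is the same kind of change as from compound 2 to compound 1, not the same: there the bromine sat on a phenyl ring para to a large group, here it sits on the fused ring system ortho to a hydroxy group and meta to a methyl group, so the earlier step cannot simply be copied. Since compound 3 stands furthest from compound 2 and compound 3 itself gives 10200 nM, removing its core bromine is expected to give a somewhat lower number in this assay, a step of a 2.9-fold lower number from compound 3 to compound 4 (0.46 log units; beyond the scatter), with wide uncertainty. Compound 4 is estimated at 3500 nM, between 700 nM and 16000 nM.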

Compound 4, half-maximal inhibitory concentration: > 20000 nM
Compound 4 gave a limit, no number; the forecaster's own chance of this, stated with the estimate: 5%; middle value at least 5.7-fold (0.75 log units) away from the limit.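

In this assay compound 4 gives > 20000 nM, which is a limit of the assay and not a number. Putting hydrogen in place of bromo on the second core gives an at least 1.9-fold higher number from compound 3 to compound 4 (0.29 log units; that floor lies within the scatter), so the result points the same way as a 6.4-fold higher number from compound 2 to compound 1 (0.81 log units; beyond the scatter), although the bromine sits in a different place in each pair and the floor of the new step cannot by itself be told from scatter. The two steps therefore do not show that the size of this change carries from one core to the other, nor do they show that it fails to carry: the same change on two cores in this assay, a 6.4-fold higher number (0.81 log units; beyond the scatter) from compound 2 to compound 1 and an at least 1.9-fold higher number (0.29 log units; that floor lies within the scatter) from compound 3 to compound 4; the limit leaves it open whether they differ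

The compounds shown leave open how a methoxy group or an amine would read in place of the bromo on the aromatic carbon ortho to the hydroxy group. They also leave the effect of the core itself open, since the cores of compound 2 and compound 3 differ in more than one place.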